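Swapping Chloro for Nitro on the Aniline Ring

The compounds below may be only part of what the source reports. "The series", "measured", "known", "first", "only" and "open" are said of these compounds alone.

Compound 1 `COc1ccc(Nc2cncc(N3CC4CC(C3)N4)c2)cc1` gives 0.0598 nM in an assay on cell membranes for displacement of a labelled ligand from Neuronal acetylcholine receptor; alpha4/beta2 (Rattus norvegicus); a higher number here means a weaker inhibitor, a lower number a stronger inhibitor.
Compound 2 `Clc1ccc(Nc2cncc(N3CC4CC(C3)N4)c2)cc1` gives 0.118 nM in this assay.
Compound 3 `Clc1ccc(Nc2cncc(N3CC4CC(C3)N4)c2)cc1Cl` gives 1.25 nM in this assay.

Among these three, compound 2 holds the second highest number: compound 1 is nearest, compound 3 furthest. The step of a 2.0-fold higher number from compound 1 to compound 2 (0.30 log units; within the scatter) stayed within the scatter, whereas an 11-fold higher number from compound 2 to compound 3 (1.03 log units; beyond the scatter) was a large loss. Compound 4 `O=[N+]([O-])c1ccc(Nc2cncc(N3CC4CC(C3)N4)c2)cc1` awaits measurement; it differs from compound 2 by nitro in place of chloro on an aromatic carbon. Going by the values given here, no measured step places a nitro group, but exchanging methoxy for chloro at the same place barely moved the number, while adding a chloro elsewhere cost much more. A small step is therefore expected, leaning toward a higher number. Compound 4 is estimated at 0.2 nM, with a range from 0.05 nM to 1 nM, which means an expected 1.7-fold higher number from compound 2 to compound 4 (0.23 log units; within the scatter).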

Compound 4, inhibition constant: 0.0225 nM
The estimate for compound 4 lay 8.9-fold (0.95 log units) above the measured number, and the stated range ends above it.
By their numbers in this assay, from the lowest: compound 4; then compounds 1 and 2 (each within the scatter of the next); then compound 3.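

The earlier swap at this aromatic carbon, para to a large group, stayed within the scatter, which made the place look indifferent to what sits there, but nitro moves the number clearly (a 5.2-fold lower number from compound 2 to compound 4 (0.72 log units; beyond the scatter)) and (a 2.7-fold lower number from compound 1 to compound 4 (0.42 log units; beyond the scatter)). Among the single groups shown here, nitro therefore gives the lowest number, while methoxy and chloro stay within the scatter of each other. No measurement shown bears on why this happens.

On these data alone, it remains open whether this gain is special to nitro, or would also appear with a nitrile, a trifluoromethyl or an amine at this carbon.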